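A few compounds are considered here, and "the series" means these few. Any claim that something is new, unique, unknown or untested is made for them only; others in the source may bear on it.

Measured so far in an assay on CHO cells for displacement of a labelled ligand from adenosine receptor A3 (Homo sapiens), read by scintillation counting, with a stated time of 3 h; a higher number here means a weaker inhibitor, a lower number a stronger inhibitor:
- compound 1 `Cc1ccc(C(=O)Nc2nc(Cl)c3cn(C)nc3n2)cc1`: 13500 nM
- compound 2 `Cc1ccc(C(=O)Nc2nc(Cl)c3cn(CC(C)(C)C)nc3n2)cc1`: 5000 nM

Compound 1 stands at the highest of the two numbers in this assay; the nearest is compound 2, and the step between them, a 2.7-fold lower number from compound 1 to compound 2 (0.43 log units; beyond the scatter) (tert-butyl in place of hydrogen on a saturated chain carbon bound to an aromatic nitrogen), is modest but beyond the scatter.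

Compound 3 `Cn1cc2c(Cl)nc(NC(=O)c3ccccc3)nc2n1` is not yet measured. It differs from compound 1 by hydrogen in place of methyl on an aromatic carbon, on an aromatic carbon of a six-membered aromatic ring of carbon only, para to a large group; cut one bond further out, 4-methylphenyl becomes phenyl. For the measured compounds named here, no measured step touches this position: the single step on record concerns the chain on the aromatic nitrogen, not the aryl amide, so nothing here indicates a direction. The expected step is therefore none beyond the scatter, no change at the digits printed from compound 1 to compound 3 (within the scatter). For compound 3 the estimate in this assay is 13500 nM, with a range from 5000 nM to 35000 nM.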

Compound 3, inhibition constant: 23600 nM
Compound 3: the middle estimate sits 1.7-fold (0.24 log units) below what was measured, and the stated range covers the measured number.
By their numbers in this assay, from the lowest: compound 2; then compounds 1 and 3 (each within the scatter of the next).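

In this assay, 4-methylphenyl to phenyl gives a 1.7-fold higher number from compound 1 to compound 3 (0.24 log units; within the scatter) and so shows that the methyl on this aromatic carbon can be exchanged for hydrogen with no effect that stands out from repeat measurement. The aryl amide position thus behaves differently in this pair from the chain on the aromatic nitrogen, where a 2.7-fold lower number from compound 1 to compound 2 (0.43 log units; beyond the scatter) lies beyond the scatter. No measured evidence bears on the reason for this result.

The compounds shown carry only methyl or hydrogen at this place, so it stays open whether a methoxy group, a chlorine atom or a longer chain would move the number beyond the scatter. Also open, going by these compounds, is whether the tert-butyl step on the chain carries over to the phenyl amide of compound 3.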